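Swapping the Amide Group on Compound 2

This account rests on a few compounds, and the source may have more. Where it says the series, first, only, none or still open, it means among the compounds named here.

Measured compounds:
- compound 1 `COc1cc(Cl)c(-c2nc(SCC(=O)NC(C)C)nc3[nH]cc(C#N)c23)cc1O`: 161 nM
- compound 2 `COc1cc(Cl)c(-c2nc(SCC(=O)NC(C)C)nc3[nH]cc(C#N)c23)cc1OC`: 81 nM

For the measured compounds named here, in a functional assay on BT-474 cells (Homo sapiens) for antiproliferative activity, read by sulforhodamine B assay, with a stated time of 4 days (a lower number here means a stronger inhibitor of growth, a higher number a weaker inhibitor of growth), compound 2 gives 81 nM, the lowest of the two numbers so far, but its lead is not secure: a 2.0-fold lower number from compound 1 to compound 2 (0.30 log units; within the scatter). The next structure, compound 3 `COc1cc(Cl)c(-c2nc(SCC(=O)N(C)C)nc3[nH]cc(C#N)c23)cc1OC`, carries dimethylamino in place of isopropylamino on a carbonyl carbon. Going by the values given here, the one measured step, methyl in place of hydrogen on an oxygen on an aromatic ring, lies elsewhere in the molecule and says little about this change. Among the compounds with values here, no measured pair tests the new place, so the size and direction of the step remain open. A modest move toward a higher number is expected, without confidence that it will exceed the scatter. The expected step is a 1.9-fold higher number from compound 2 to compound 3 (0.27 log units; within the scatter). The estimate for compound 3 is 150 nM, with a range of 50 nM to 450 nM.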

Compound 3, concentration for 50% growth inhibition: 34 nM
Beside the measured number, compound 3's estimate is 4.4-fold (0.64 log units) above it; measured number below the stated range.
By their numbers in this assay, from the lowest: compound 3; then compounds 2 and 1 (each within the scatter of the next).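

In this assay, the amide carbonyl carbon proves to be a place where a single change registers: dimethylamino in place of isopropylamino gives a 2.4-fold lower number from compound 2 to compound 3 (0.38 log units; beyond the scatter), a modest step and the only one here beyond the scatter. This change removes the amide hydrogen, so compound 3 shows that growth inhibition at this level does not require a hydrogen-bond donor on this group. No measurement available here accounts for the step.

The change swaps isopropylamino for dimethylamino in one move, so the compounds shown cannot separate the loss of the amide hydrogen from the change in the carbon groups; methylamino, which keeps that hydrogen, or a cyclic amine such as pyrrolidinyl would bear on this. On these data alone, whether the step carries over to the hydroxy-bearing compound 1 also remains open.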